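Swapping Ethyl for Hydroxymethyl on the Shared Core

The compounds below may be only part of what the source reports. "The series", "measured", "known", "first", "only" and "open" are said of these compounds alone.

Compound 1 (`COc1cc(C(=O)c2cccc3c2ccn3C)cc(OC)c1OC`): 21.6 nM
Compound 2 (`CCn1ccc2cc(C(=O)c3cc(OC)c(OC)c(OC)c3)ccc21`): 31 nM

Both values come from a functional assay on MKN-45 cells (Homo sapiens) for inhibition, with a stated time of 72 h; on this read-out higher numbers stand for weaker inhibition and lower numbers for stronger inhibition. Compound 2 stands within the usual scatter of compound 1, so repeated measurements could not reliably separate the two, and they cannot be ranked.

Compound 3 (`COc1cc(C(=O)c2ccc3c(ccn3CO)c2)cc(OC)c1OC`) has not yet been measured. Its difference from compound 2 is hydroxy in place of methyl on a saturated chain carbon bound to an aromatic nitrogen (hydroxy in place of methyl on a saturated chain carbon bound to an aromatic nitrogen, which turns ethyl into hydroxymethyl).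

Within the data shown here, no measured pair here shows a change of this kind, so the data give no direct guide to its size. In this assay a modest step toward weaker inhibition is expected, although a step lost within the scatter remains quite possible. The estimated change is a 1.8-fold higher number from compound 2 to compound 3 (0.25 log units; within the scatter) and it carries wide uncertainty. Among the measured compounds shown here, this expectation is anchored on compound 2 at 31 nM and on the single structural change. For compound 3 the estimated value is 55 nM with an expected range from 15 nM to 200 nM around it.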

Compound 3, half-maximal inhibitory concentration: 33 nM
Estimate against measurement, compound 3: 1.7-fold (0.22 log units) above; measured number inside the range.
By their numbers in this assay, from the lowest: compounds 1, 2 and 3 (each within the scatter of the next).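

In this assay, putting hydroxy in place of methyl on a saturated chain carbon bound to an aromatic nitrogen, which turns ethyl into hydroxymethyl, gives a 1.1-fold higher number from compound 2 to compound 3 (0.03 log units; within the scatter), so this assay cannot tell the two compounds apart. Among these compounds, this pair is the first direct look at this place on the shared core: the entering hydroxy brings a hydrogen-bond donor and a hydrogen-bond acceptor that the methyl lacks, yet the step stays well within the usual scatter of repeated measurements. Nothing available alongside these numbers bears on what lies behind this result.

From the compounds shown here alone, what remains open is how far this tolerance extends, for example whether a longer chain, an amine or a carboxylic acid at this same place would also stay within the scatter or would produce a step that could be read clearly. A single pair also cannot show whether hydroxy in place of methyl would give a similar result elsewhere on the shared core or in another assay.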